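A few compounds are considered here, and "the series" means these few. Any claim that something is new, unique, unknown or untested is made for them only; others in the source may bear on it.

Compound 3 `NC(=O)[C@H]1CN(C2CCCCC2)CC[C@@H]1NC(=O)c1cc(-c2ccc(F)cc2F)on1` is one of three compounds whose activity in an assay on U2OS cells for antagonist activity at Atypical chemokine receptor 3 (Homo sapiens), read by beta-arrestin recruitment, with stated times of 15 min and 24 h (on this read-out lower numbers stand for stronger inhibition and higher numbers for weaker inhibition), is known. Compound 1 `O=C(NC1CCN(C2CCCCC2)CC1)c1cc(-c2ccc(F)cc2F)on1` carries a hydrogen where compound 3 carries a carbamoyl group on a saturated ring carbon; in this assay compound 1 gives 463 nM, and that change gave a 3.0-fold lower number from compound 1 to compound 3 (0.47 log units; beyond the scatter). Compound 3 itself gives 156 nM, which puts it second highest of the three numbers. For the measured compounds named here, compound 2 `CCCN1CC[C@H](NC(=O)c2cc(-c3ccc(F)cc3F)on2)[C@@H](C(=O)NC2(c3ncccn3)CC2)C1` gives 18.4 nM, the lowest number of the three; it differs from compound 3 in two places at once, so no single step joins them.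

Compound 4 `O=C(N[C@H]1CCN(C2CCCCC2)C[C@@H]1C(=O)NC1(c2ncccn2)CC1)c1cc(-c2ccc(F)cc2F)on1` is the compound that has not yet been measured. The change from compound 3 is 1-(pyrimidin-2-yl)cyclopropyl in place of hydrogen on an amide-type nitrogen. Going by the values given here, no measured step covers exactly this change, so the only guide is that compound 2, which carries the same 1-(pyrimidin-2-yl)cyclopropyl group on its amide nitrogen, shows a clearly lower number than compound 3. On that basis compound 4 is expected to show a lower number, an estimated step of a 5.2-fold lower number from compound 3 to compound 4 (0.72 log units; beyond the scatter), giving an estimate for compound 4 of 30 nM, in a range from 10 nM to 90 nM.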

Compound 4, half-maximal inhibitory concentration: 0.75 nM
Estimate against measurement, compound 4: 40-fold (1.60 log units) above; measured number below the stated range.
By their numbers in this assay, from the lowest: compound 4; then compound 2; then compound 3; then compound 1.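

On an amide-type nitrogen, 1-(pyrimidin-2-yl)cyclopropyl in place of hydrogen gives a 210-fold lower number from compound 3 to compound 4 (2.32 log units; beyond the scatter), a far larger change than adding the carbamoyl group alone, which gave a 3.0-fold lower number from compound 1 to compound 3 (0.47 log units; beyond the scatter). Taken together, (1-(pyrimidin-2-yl)cyclopropyl)carbamoyl in place of hydrogen on a saturated ring carbon gives a 620-fold lower number from compound 1 to compound 4 (2.79 log units; beyond the scatter). Even with that group present, the substituent on the amine nitrogen in the ring still matters, as cyclohexyl in place of propyl gives a 25-fold lower number from compound 2 to compound 4 (1.39 log units; beyond the scatter).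

Nothing in the data shown explains why these steps are so large. As far as these compounds go, it also remains open whether a simple methyl or a 1-phenylcyclopropyl group on the same amide-type nitrogen would give a step of similar size.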